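Adding an isopropyl to a compound stuck at a limit

The source may report more compounds than this note shows. Statements on the series, on what has been measured and on what is new or still open speak of the compounds shown alone.

In a functional assay on HepG2 cells (Homo sapiens) for antiproliferative activity, read by MTT assay, with a stated time of 72 h (a higher number here means a weaker inhibitor, a lower number a stronger inhibitor), compound 3 `COc1ccc(N2C(=O)COc3ccc(-c4ccc(O)cc4)cc32)cc1` reads 10800 nM as a measured number. Compound 1 `COc1cccc(N2C(=O)COc3ccc(-c4cnc(Cl)c(NS(=O)(=O)c5ccc(F)cc5)c4)cc32)c1` stands at > 40000 nM as a limit and not a number. Compound 2 `O=C1COc2ccc(-c3cccc(NS(=O)(=O)c4ccc(F)cc4)c3)cc2N1` sits at > 40000 nM which is also a limit, so it has no exact value here. The change to compound 4 `CC(C)N1C(=O)COc2ccc(-c3cccc(NS(=O)(=O)c4ccc(F)cc4)c3)cc21` is isopropyl in place of hydrogen on an amide-type nitrogen in a ring and in words it is isopropyl in place of hydrogen on an amide-type nitrogen in a ring. For the measured compounds named here, no measured pair shows this change alone. In this assay a small move toward a lower number is expected because compound 3 reads 10800 nM as a true number, though compound 1 goes against this. The expected size of the step of an at least 1.6-fold lower number from compound 2 to compound 4 (0.20 log units; that floor lies within the scatter) is small, and another limit may appear. For compound 4 the estimate is 25000 nM with an expected range from 8000 nM to 60000 nM in this reading.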

Compound 4, half-maximal inhibitory concentration: > 40000 nM
Compound 4: no number, only a limit; the forecaster's own chance of this, stated with the estimate: 50%; middle value at least 1.6-fold (0.20 log units) away from the limit.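

For the compounds shown here, compound 2 and compound 4 both stand at a limit rather than a number, so no step between them can be read: the limit of > 40000 nM in this assay, at which 3 of the 4 values shown sit. The compounds shown leave open whether isopropyl in place of hydrogen on this nitrogen changes the reading at all.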